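The compounds below may be only part of what the source reports. "The series", "measured", "known", "first", "only" and "open" are said of these compounds alone.

Of the compounds shown here, three from one series have been tested in a functional assay on HeLa cells (Homo sapiens) for cytotoxicity, read by MTT assay, with a stated time of 24 h; on this read-out higher numbers stand for weaker inhibition and lower numbers for stronger inhibition. Compound 1 `O=c1nc2ccc(Br)cn2cc1Cc1ccc(Cl)cc1` carries a bromo on its fused core and a chloro on the pendant ring. In this assay compound 1 reaches only the limit of > 1000000 nM. Compound 2 `O=c1nc2ccc(Cl)cn2cc1Cc1ccc(F)cc1` carries a chloro on the fused core and a fluoro on the pendant ring; the difference between the two cores of compound 1 and compound 2 is not broken down here. In this assay compound 2 likewise sits at the limit of > 1000000 nM. Compound 3 `O=c1nc2ccc(Br)cn2cc1Cc1ccccc1` keeps the core of compound 1 but has hydrogen in place of chloro on an aromatic carbon of the pendant ring, and in this assay compound 3 gives 152000 nM, which is an at least 6.5-fold lower number from compound 1 to compound 3 (0.81 log units; beyond the scatter) (hydrogen in place of chloro on an aromatic carbon). Two of the three values sit at the limit of > 1000000 nM in this assay, at which 2 of the 3 values shown sit.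

Compound 4 `O=c1nc2ccccn2cc1Cc1ccc(F)cc1` is not yet measured. It differs from compound 2 by hydrogen in place of chloro on an aromatic carbon, the same kind of change as from compound 1 to compound 3, but made on the fused core rather than on the carbon-only ring para to a large group. Since compound 2 sits at a limit, the step can only be guessed, and compound 4 is expected to move by an at least 1.6-fold lower number from compound 2 to compound 4 (0.22 log units; that floor lies within the scatter). Compound 4 is therefore estimated at 600000 nM, between 150000 nM and 3000000 nM.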

Compound 4, half-maximal inhibitory concentration: 139000 nM
Compound 4: the middle estimate sits 4.3-fold (0.64 log units) above what was measured; the whole stated range lies above it.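

In this assay, hydrogen in place of chloro on an aromatic carbon of the fused core gives an at least 7.1-fold lower number from compound 2 to compound 4 (0.85 log units; beyond the scatter). Hydrogen in place of chloro thus lowers the number in both pairs, once on the pendant ring and once on the fused core, so the direction of the change carries over in these two cases, though two pairs do not make a rule for the series, and how far the size carries over stays unsettled: the same change on two cores in this assay, an at least 6.5-fold lower number (0.81 log units; beyond the scatter) from compound 1 to compound 3 and an at least 7.1-fold lower number (0.85 log units; beyond the scatter) from compound 2 to compound 4; the limit leaves it open whether they differ. Both steps start from a limit of the assay rather than a number, so each gives only a floor and neither gives a true size: the limit of > 1000000 nM in this assay, at which 2 of the 4 values shown sit.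

The compounds shown leave open whether removing a bromo from the fused core would act as removing the chloro does, and whether the pendant fluoro matters on its own. They also leave open what an amine, a methoxy group or a carboxylic acid would do at these ring carbons.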